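A Carbonyl Step Toward Compound 4

A few compounds are considered here, and "the series" means these few. Any claim that something is new, unique, unknown or untested is made for them only; others in the source may bear on it.

In a functional assay on MDA-MB-231 cells (Homo sapiens) for antiproliferative activity, read by MTT assay, with a stated time of 24 h (a higher number here means a weaker inhibitor, a lower number a stronger inhibitor), compound 2 `O=C(NNc1ccc(F)cc1)c1cccc(NS(=O)(=O)c2cnc(O)nc2O)c1` reads > 20000 nM as a limit, not a number. Compound 1 `Cc1ccccc1NNC(=O)c1ccc(NS(=O)(=O)c2cnc(O)nc2O)cc1` reads > 20000 nM as a limit too. Compound 3 `Cc1ccccc1C(=O)NNC(=O)c1ccc(NS(=O)(=O)c2cnc(O)nc2O)cc1` reads 7040 nM as a true number. Compound 4 `O=C(NNC(=O)c1ccccc1F)c1cccc(NS(=O)(=O)c2cnc(O)nc2O)c1` carries (2-fluorophenyl)carbonyl in place of 4-fluorophenyl on an amine nitrogen. Within the data shown here, one measured step bears on this. Going by an at least 2.8-fold lower number from compound 1 to compound 3 (0.45 log units; beyond the scatter) where (2-methylphenyl)carbonyl replaced 2-methylphenyl on an amine nitrogen, a step of similar size toward a lower number is expected in this assay for compound 4, although the two pairs differ elsewhere. The estimated move is an at least 2.2-fold lower number from compound 2 to compound 4 (0.34 log units; beyond the scatter) and it may still end at the limit. Compound 4 is estimated at 9000 nM (expected range 3500 nM to 20000 nM).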

Compound 4, half-maximal inhibitory concentration: > 20000 nM
Compound 4: only a limit was reported; the forecaster's own chance of this, stated with the estimate: 35%; middle value at least 2.2-fold (0.34 log units) away from the limit.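

Compound 2 and compound 4 both stand only as limits in this assay, so no step between them can be read: the limit of > 20000 nM in this assay, at which 3 of the 4 values shown sit.

The compounds shown leave open whether (2-fluorophenyl)carbonyl in place of 4-fluorophenyl changes the activity at all.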